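A few compounds are considered here, and "the series" means these few. Any claim that something is new, unique, unknown or untested is made for them only; others in the source may bear on it.

Of the compounds shown here, three built on a shared core have been measured in a functional assay on MKN-45 cells (Homo sapiens) for inhibition, with a stated time of 72 h; on this read-out lower numbers stand for stronger inhibition and higher numbers for weaker inhibition. Compound 1 `COc1ccc(S(=O)(=O)N2CCc3cccc(-c4ccc(O)cc4)c32)cc1` gives 82.6 nM. Compound 2 `COc1ccc(S(=O)(=O)N2CCc3cccc(-c4ccc(N(C)C)cc4)c32)cc1` gives 237 nM. Compound 3 `COc1ccc(S(=O)(=O)N2CCc3cccc(-c4cccs4)c32)cc1` gives 165 nM, which puts compound 3 at the second highest of the three numbers, with a 1.4-fold lower number from compound 2 to compound 3 (0.16 log units; within the scatter) and a 2.0-fold higher number from compound 1 to compound 3 (0.30 log units; within the scatter) both leaving it within the scatter of its neighbours. For the measured compounds named here, the one step among the three that reaches beyond the scatter is a 2.9-fold higher number from compound 1 to compound 2 (0.46 log units; beyond the scatter).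

Compound 4 `COc1ccc(S(=O)(=O)N2CCc3cccc(-c4ccc(N)cc4)c32)cc1` differs from compound 3 in one place: 4-aminophenyl in place of thiophen-2-yl on an aromatic carbon. The measured steps that bear on this change are the two that swap the same group at the same place on the shared core, a 2.0-fold higher number from compound 1 to compound 3 (0.30 log units; within the scatter) and a 1.4-fold lower number from compound 2 to compound 3 (0.16 log units; within the scatter), and both were within the scatter. The group that enters in compound 4 carries a hydrogen-bond donor, as does the group in compound 1, and compound 1 gives the lowest of the three numbers, so a modest move toward compound 1 is expected, a 1.7-fold lower number from compound 3 to compound 4 (0.22 log units; within the scatter), though a step within the scatter would also fit the data shown. The value of compound 4 in this assay is therefore estimated at 100 nM, within a range of 40 nM to 250 nM.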

Compound 4, half-maximal inhibitory concentration: 162 nM
For compound 4 the middle estimate is 1.6-fold (0.21 log units) below the measured one; the range from low to high includes it.
By their numbers in this assay, from the lowest: compounds 1, 4, 3 and 2 (each within the scatter of the next, the first and the last beyond it).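

In this assay, swapping thiophen-2-yl for 4-aminophenyl at this aromatic carbon gives a 1.0-fold lower number from compound 3 to compound 4 (0.01 log units; within the scatter), so a five-membered ring with 0 hydrogen-bond donors and a six-membered ring with 1 hydrogen-bond donor cannot be told apart here. The group on the phenyl ring can also be varied without a step beyond the scatter on either side of compound 4: amino in place of dimethylamino gives a 1.5-fold lower number from compound 2 to compound 4 (0.17 log units; within the scatter), and amino in place of hydroxy gives a 2.0-fold higher number from compound 1 to compound 4 (0.29 log units; within the scatter), which leaves compound 4 within the scatter of both although compound 1 and compound 2 lie beyond it from each other. Nothing measured alongside these numbers offers an explanation for them.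

Going by these compounds, it remains open whether a carboxylic acid or an aminomethyl group in place of the amino group of compound 4 would give a step beyond the scatter. On these data alone, it is also open whether a longer chain on that phenyl ring, such as ethoxy in place of the hydroxy group of compound 1, would keep a number close to that of compound 1 or move it away.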